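Plasma half-life of a fourth diester on the shared core

The compounds below may be only part of what the source reports. "The series", "measured", "known", "first", "only" and "open" are said of these compounds alone.

Measured compounds:
compound 1 `CC(=O)Oc1ccccc1C(=O)O[C@H]1CO[C@H]2[C@@H]1OC[C@H]2OC(=O)c1ccc(O)cc1`, 0.0198 h
compound 2 `CCCCC(=O)O[C@@H]1CO[C@H]2[C@@H]1OC[C@@H]2OC(=O)c1ccccc1OC(C)=O`, 0.0117 h
compound 3 `COc1ccccc1C(=O)O[C@@H]1CO[C@H]2[C@@H]1OC[C@@H]2OC(=O)c1ccccc1OC(C)=O`, 0.0165 h

All three numbers come from an ADME assay on a cell-free system (plasma, Homo sapiens) for metabolic stability, with Plasma (Rattus norvegicus) as the target, read by HPLC, at pH 7.4 (on this read-out higher numbers stand for a longer-lived compound and lower numbers for a shorter-lived compound), and lie close together. The steps among them, a 1.7-fold lower number from compound 1 to compound 2 (0.23 log units; within the scatter), a 1.2-fold lower number from compound 1 to compound 3 (0.08 log units; within the scatter) and a 1.4-fold higher number from compound 2 to compound 3 (0.15 log units; within the scatter), each exchange the group on one carbonyl carbon of the shared core, and none of them reaches beyond the scatter, so compound 2 cannot be set apart from compound 1 or compound 3 on these numbers.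

Compound 4 `CC(=O)Oc1ccccc1C(=O)O[C@H]1CO[C@H]2[C@@H]1OC[C@H]2OC(=O)CO[N+](=O)[O-]` differs from compound 2 by nitrooxy in place of propyl on a saturated chain carbon bound to a carbonyl carbon. Among the measured compounds shown here, no measured step introduces a nitrooxy group, so the three acyl exchanges above are the only guide; since each stayed within the scatter, a similarly small step is expected here, with no direction that can be called. The estimate for compound 4 in this assay is therefore 0.012 h, with a range from 0.004 h to 0.035 h, which means an expected step of a 1.0-fold higher number from compound 2 to compound 4 (0.01 log units; within the scatter).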

Compound 4, half-life: 0.015 h
Compound 4: the middle estimate sits 1.3-fold (0.10 log units) below what was measured, and the stated range covers the measured number.
By their numbers in this assay, from the lowest: compounds 2, 4, 3 and 1 (each within the scatter of the next).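

In this assay, nitrooxy in place of propyl on a saturated chain carbon bound to a carbonyl carbon gives a small step (a 1.3-fold higher number from compound 2 to compound 4 (0.11 log units; within the scatter)), so this acyl position also accepts a group of nitrogen and oxygen atoms, with its hydrogen-bond acceptors, without leaving the scatter. The (nitrooxy)methyl group also cannot be told apart from the two aryl groups on a carbonyl carbon (a 1.1-fold lower number from compound 3 to compound 4 (0.04 log units; within the scatter); a 1.3-fold lower number from compound 1 to compound 4 (0.12 log units; within the scatter)), so all four acyl groups shown give half-lives that cannot be separated. Nothing in the data shown explains why these numbers stay so close.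

On these data alone, whether an amine or a carboxylic acid on this chain, or a much longer chain, would move the half-life beyond the scatter remains open. So does the effect of changing the other ester group, which is the same in all four compounds.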